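Swapping dimethylamino for acetyl on the shared core

The source may report more compounds than this note shows. Statements on the series, on what has been measured and on what is new or still open speak of the compounds shown alone.

Compound 1 `COc1cc(C)cc(-c2c(-c3ccnc(-c4ccc(N(C)C)cc4)c3)cnn2CC#N)c1` carries a dimethylamino group on the outer phenyl ring and is the starting point of this account. In a functional assay on IGROV-1 cells (Homo sapiens) for inhibition, read by sulforhodamine B assay, with a stated time of 48 h (on this read-out higher numbers stand for lower toxicity in this test and lower numbers for higher toxicity in this test), compound 1 gives > 100000 nM, which is a limit of the assay and not a number. Compound 2 `COc1cc(C)cc(-c2nn(CC#N)cc2-c2ccnc(-c3ccc(N(C)C)cc3)c2)c1` is a close relative of compound 1 and in this assay compound 2 likewise gives > 100000 nM, again a limit rather than a measured value. Among the measured compounds shown here, compound 3 `Cc1cc(O)cc(-c2nn(CC#N)cc2-c2ccnc(-c3ccc(Oc4ccccc4)cc3)c2)c1` differs at several places and is the only compound of the three with a number: in this assay compound 3 gives 8070 nM. Compound 1 therefore stands at the limit, and the limit of > 100000 nM in this assay, at which 2 of the 3 values shown sit, shows that compound 2 sits there with it.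

The next compound, compound 4 `COc1cc(C)cc(-c2c(-c3ccnc(-c4ccc(C(C)=O)cc4)c3)cnn2CC#N)c1`, differs from compound 1 in one place (acetyl in place of dimethylamino on an aromatic carbon). For the measured compounds named here, no measured step between two compounds of this set tells how such a change plays out in this assay, so the expectation rests on the limit of compound 1 alone. Compound 4 is expected to show an at least 1.6-fold lower number from compound 1 to compound 4 (0.22 log units; that floor lies within the scatter), with a real chance that the assay again reports only a limit. The estimate for compound 4 is 60000 nM, expected to lie between 10000 nM and 100000 nM.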

Compound 4, concentration lethal to 50% of the cells: > 100000 nM
Compound 4 was reported as a limit; the forecaster's own chance of this, stated with the estimate: 55%; at least 1.6-fold (0.22 log units) between middle value and limit.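

In this assay compound 4 gives > 100000 nM, a limit of the assay and not a number. Compound 1 is also reported only as a limit, so no step can be read between compound 1 and compound 4: the limit of > 100000 nM in this assay, at which 3 of the 4 values shown sit.

The compounds shown leave open whether acetyl in place of dimethylamino changes the read-out in this assay at all.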